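The source may hold more compounds than are shown below. What is called first, only, known or untested is meant among the compounds shown, and "the series" means these compounds.

Measured so far:
Compound 1 `CSCC[C@H](NC(=O)c1ccc(CN(Cc2ccccc2)c2cnccn2)cc1-c1ccccc1C)C(=O)O` gives < 0.4 h as a limit of the assay
Compound 2 `CSCC[C@H](NC(=O)c1ccc(CN(Cc2ccccc2)c2ccccc2)cc1-c1ccccc1C)C(=O)O` gives 0.8 h

Going by the values given here, in an ADME assay on the whole organism for metabolic stability, with Rattus norvegicus as the target (on this read-out lower numbers stand for a shorter-lived compound and higher numbers for a longer-lived compound), compound 2 gives 0.8 h as the only actual number. Compound 1 has only a limit. Among the compounds with values here, compound 3 `CSCC[C@H](NC(=O)c1ccc(CN(Cc2ccccc2)Cc2cncs2)cc1-c1ccccc1C)C(=O)O` carries (1,3-thiazol-5-yl)methyl in place of phenyl on an amine nitrogen as its one change. Within the data shown here, the single measured step that bears on this is an at least 2.0-fold higher number from compound 1 to compound 2 (0.30 log units; that floor lies within the scatter) and it rests on the limit of < 0.4 h in this assay, at which 1 of the 2 values shown sits, so its true size stays open. There phenyl also stands against a ring with hetero atoms, and that ring gave the lower result. The expected step is a 1.6-fold lower number from compound 2 to compound 3 (0.20 log units; within the scatter) in this assay as a small move toward a shorter life, within the scatter. For compound 3 the estimate is 0.5 h with 0.2 h to 1.2 h as the expected range.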

Compound 3, half-life: < 0.4 h
Compound 3 ended at the assay's limit; the forecaster's own chance of this, stated with the estimate: 30%; middle value at least 1.2-fold (0.09 log units) from the limit.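

In this assay, (1,3-thiazol-5-yl)methyl in place of phenyl on this amine nitrogen gives an at least 2.0-fold lower number from compound 2 to compound 3 (0.30 log units; that floor lies within the scatter). Compound 2, with phenyl, thus remains the only one of the three with an actual number, while a second group with hetero atoms, after pyrazin-2-yl in compound 1, ends at a limit. The step from compound 1 to compound 3 cannot be read, and the size of the new step stays open because of where the values sit: the limit of < 0.4 h in this assay, at which 2 of the 3 values shown sit.

The compounds shown leave open whether the hetero atoms or the methyl link carries this step. A benzyl group on this nitrogen, the carbon-only counterpart of (1,3-thiazol-5-yl)methyl, would separate the two.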